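Hexyl in place of phenyl, starting from a limit

The source may hold more compounds than are shown below. What is called first, only, known or untested is meant among the compounds shown, and "the series" means these compounds.

Compound 1 `CCCNC(=O)c1cc(-n2cc(-c3ccccc3)nn2)ccc1O`: > 20000 nM (a limit)
Compound 2 `CCCNC(=O)c1cc(-n2cc(CCC(C)C)nn2)ccc1O`: > 20000 nM (a limit)

In a functional assay on RAW264.7 cells (Mus musculus) for inhibition, read by Griess assay, with a stated time of 20 h (on this read-out higher numbers stand for weaker inhibition and lower numbers for stronger inhibition), compound 1 gives no number, only the limit (> 20000 nM). Compound 2 likewise gives only a limit (> 20000 nM). The unmeasured compound 3 `CCCCCCc1cn(-c2ccc(O)c(C(=O)NCCC)c2)nn1` carries hexyl in place of phenyl on an aromatic carbon. For the measured compounds named here, the one measured step bearing on this is a step that the two limits leave unreadable from compound 1 to compound 2 (isopentyl in place of phenyl on an aromatic carbon), and it gives no size to carry over. With the limit of > 20000 nM in this assay, at which 2 of the 2 values shown sit, as the whole of the evidence, a clear gain in inhibition is not expected, and compound 3 will probably stay near that limit. The estimated step is a number no higher from compound 1 to compound 3 (the limit leaves the size open) (no firm direction). The expected value for compound 3 is 20000 nM (range 8000 nM to 40000 nM).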

Compound 3, half-maximal inhibitory concentration: 19700 nM
Beside the measured number, compound 3's estimate is 1.0-fold (0.01 log units) above it, within the range that was stated.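

For the compounds shown here, with hexyl in place of phenyl, compound 3 gives the first actual number at this position in this assay, reading 19700 nM. Set against the two earlier compounds, the steps are an at least 1.0-fold lower number from compound 1 to compound 3 (0.00 log units; that floor lies within the scatter) and an at least 1.0-fold lower number from compound 2 to compound 3 (0.00 log units; that floor lies within the scatter), so the change from a ring to an open chain of the same heavy-atom count shows no gain beyond the scatter. The true values of compound 1 and compound 2 remain unknown, and a floor within the scatter is all these steps can give: the limit of > 20000 nM in this assay, at which 2 of the 3 values shown sit.

Only phenyl, isopentyl and hexyl are shown on this aromatic carbon, and none of them gives a number clearly under the limit. On these data alone, what a longer chain, or a chain ending in an amine or a carboxylic acid, would read here stays open.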